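A Fluorine Added Beside Nothing Yet Measured

The source may hold more compounds than are shown below. What is called first, only, known or untested is meant among the compounds shown, and "the series" means these compounds.

Measured so far:
- Compound 1, `Oc1ccccc1CNc1ccc(-c2ccc(-c3ccccc3)cc2)cc1`: "not active" (no number reported)
- Compound 2, `CCOc1ccc(-c2ccc(NCc3ccccc3O)cc2)cc1`: 520 nM
- Compound 3, `COC(=O)c1ccc(-c2ccc(NCc3ccccc3O)cc2)cc1`: "not active" (no number reported)

These three share one core and differ only in the group at the far end. In a functional assay on Jurkat cells (Homo sapiens) for activation, with a stated time of 24 h (on this read-out higher numbers stand for an effect only at larger amounts of compound and lower numbers for an effect already at smaller amounts), compound 2 gives 520 nM, and it is the only one of the three with a number at all: compound 1 is reported as "not active" (no number reported), and compound 3 likewise as "not active" (no number reported), with no number behind either report. Compound 2 therefore stands alone; nothing can be said about how far it lies from the other two, only that they gave no measurable effect.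

Compound 4, `CCOc1ccc(-c2ccc(NCc3ccccc3O)cc2)cc1F`, has not yet been measured. It differs from compound 2 in one spot: fluoro in place of hydrogen on an aromatic carbon. Among the compounds with values here, no measured pair shows what such a change does here, so there is no step to lean on. Compound 4 is estimated at 450 nM, with a range from 150 nM to 1500 nM. This estimate means a step of a 1.2-fold lower number from compound 2 to compound 4 (0.06 log units; within the scatter) that is expected to stay within the usual scatter, in no particular direction.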

Compound 4, half-maximal effective concentration: 2530 nM
The estimate for compound 4 lay 5.6-fold (0.75 log units) below the measured number; measured number outside the range, above it.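

Within the data shown here, this is the first measured step, and it shows that this position is not indifferent to change. In this assay, fluoro in place of hydrogen on an aromatic carbon ortho to an ethoxy group gives a 4.9-fold higher number from compound 2 to compound 4 (0.69 log units; beyond the scatter), so a single added heavy atom at this spot is enough to move the number beyond the usual scatter, towards an effect only at larger amounts of compound. Nothing in the data shown gives a measured reason for this step.

Going by these compounds, it remains open whether this step is specific to fluoro or would also appear with another group on the same carbon, such as a chlorine atom, a methyl group or an amine. Also open, on these data alone, is how a fluoro at this spot would behave with a longer chain, such as propoxy, in place of the ethoxy group.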